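The source may report more compounds than this note shows. Statements on the series, on what has been measured and on what is new or still open speak of the compounds shown alone.

Compound 1 `CCc1ccc(OCC(=O)N(CC)Cc2cccs2)cc1`: 67 nM
Compound 2 `COc1ccc(OCC(=O)N(Cc2cccs2)c2ccn[nH]2)cc1`: 3.7 nM

Both measured compounds were tested in an assay on HEK293 cells for agonist activity at transient receptor potential cation channel subfamily M member 8 (Homo sapiens), read by fluorescence and calcium flux, with a stated time of 15 min; on this read-out lower numbers stand for an effect already at smaller amounts and higher numbers for an effect only at larger amounts of compound. Of the two numbers shown, compound 1 gives the higher one, 67 nM. Its nearest neighbour, compound 2, gives 3.7 nM, and the gap between the two lies beyond the usual scatter of this kind of measurement. Compound 3 `CCN(Cc1cccs1)C(=O)COc1ccc(C(=O)O)cc1` has not yet been measured. It differs from compound 1 in a single place: carboxy in place of ethyl on an aromatic carbon. Among the measured compounds shown here, no pair of measured compounds shows what this kind of change does on this read-out, so the expectation rests on the structural change alone and carries real uncertainty. For compound 3 the step of a 6.0-fold higher number from compound 1 to compound 3 (0.78 log units; beyond the scatter) is expected to run toward higher numbers, by more than the scatter. Compound 3 is therefore estimated at 400 nM, with a range from 100 nM to 2000 nM.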

Compound 3, half-maximal effective concentration: "not active" (no number reported)
For compound 3 the study gives words and no number; there is nothing to compare the estimate with.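

Among the compounds shown here, compound 3 is reported in words only, with no number, so no step from compound 1 to compound 3 can be read. Nothing shown bears on why this result arose. The compounds shown leave open how large the effect of swapping ethyl for carboxy is on this read-out.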